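Adding one methyl to the ethyl chain of compound 2

The compounds below may be only part of what the source reports. "The series", "measured", "known", "first", "only" and "open" are said of these compounds alone.

Measured in a functional assay on SW1573 cells (Homo sapiens) for antiproliferative activity, read by sulforhodamine B assay, with a stated time of 48 h; a lower number here means a stronger inhibitor of growth, a higher number a weaker inhibitor of growth:
- compound 1 `COC(=O)C#CC(O/C=C/C(=O)OC)C(C)c1ccccc1`: 1200 nM
- compound 2 `CCC(C#CC(=O)OC)O/C=C/C(=O)OC`: 540 nM

Of these two numbers, compound 2 has the lower at 540 nM, so it is the stronger inhibitor of growth so far. Compound 3 `CCCC(C#CC(=O)OC)O/C=C/C(=O)OC` differs from compound 2 in one place, where ethyl becomes propyl: methyl in place of hydrogen on a saturated chain carbon, three bonds along the chain from an oxygen on an unsaturated carbon and a triple-bonded carbon.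

Going by the values given here, only one measured step bears on this change: a 2.2-fold lower number from compound 1 to compound 2 (0.35 log units; beyond the scatter). That step replaced a whole phenyl with hydrogen, which is a much larger edit than adding one methyl, and its effect on the number was still modest. It is also a different kind of change, so it gives only a rough sense of scale and does not settle the direction. In this assay, a small step at most is therefore expected, quite possibly none beyond the scatter.

The expected change is a 1.1-fold higher number from compound 2 to compound 3 (0.05 log units; within the scatter). The estimate for compound 3 is 600 nM, with an expected range of 250 nM to 1300 nM.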

Compound 3, concentration for 50% growth inhibition: 320 nM
Estimate against measurement, compound 3: 1.9-fold (0.27 log units) above; the range from low to high includes it.
By their numbers in this assay, from the lowest: compounds 3 and 2 (each within the scatter of the next); then compound 1.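

In this assay the change from ethyl to propyl gives a 1.7-fold lower number from compound 2 to compound 3 (0.23 log units; within the scatter) and so cannot be told apart from repeat-to-repeat variation, which means that this added methyl causes no measurable loss of growth inhibition. Going by these compounds alone, the earlier step, a 2.2-fold lower number from compound 1 to compound 2 (0.35 log units; beyond the scatter) and thus beyond the scatter, involved swapping a phenyl for hydrogen on a different chain carbon and said nothing about chain length, whereas this pair gives the first direct reading of it. No measurement shown here offers an explanation for either step.

Two neighbouring chains cannot show how far this tolerance extends, so a longer chain such as butyl or pentyl could either hold the number steady or begin to move it beyond the scatter. As far as these compounds go, it also remains open whether this end of the chain accepts only plain carbon or can carry a different kind of group, such as a hydroxyl, an amine or a carboxylic acid.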